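Shortening the nitroimidazole linker on a quinazoline anilide

The source may hold more compounds than are shown below. What is called first, only, known or untested is meant among the compounds shown, and "the series" means these compounds.

Measured so far, in a functional assay on HT-29 cells (Homo sapiens) for cytotoxicity, read by sulforhodamine B assay, with a stated time of 72 h; a lower number here means a stronger inhibitor, a higher number a weaker inhibitor:
compound 1 `COc1cc2ncnc(Nc3ccc(F)c(Cl)c3)c2cc1OCCCCn1ccnc1[N+](=O)[O-]` gives 2210 nM;
compound 2 `C#Cc1cccc(Nc2ncnc3cc(OC)c(OCCCn4ccnc4[N+](=O)[O-])cc23)c1` gives 5550 nM;
compound 3 `COc1cc2ncnc(Nc3ccc(OCc4cccc(F)c4)c(Cl)c3)c2cc1OCCCCn1ccnc1[N+](=O)[O-]` gives 1870 nM.

Compound 1 sits second highest of these three numbers. Its nearest neighbour is compound 3, reached by a 1.2-fold lower number from compound 1 to compound 3 (0.07 log units; within the scatter), a step that lies within the scatter. For the measured compounds named here, compound 2, which differs from compound 1 in two places at once, shows a clearly higher number in this assay, but no single-change step connects the two.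

Compound 4 `COc1cc2ncnc(Nc3ccc(F)c(Cl)c3)c2cc1OCCn1c([N+](=O)[O-])cnc1C` arises from compound 1 through (2-methyl-5-nitro-1H-imidazol-1-yl in place of 2-(2-nitro-1H-imidazol-1-yl)ethyl on a saturated chain carbon, two bonds along the chain from an oxygen on an aromatic ring). Cut one bond further out, the same change reads 3-(2-nitro-1H-imidazol-1-yl)propyl to (2-methyl-5-nitro-1H-imidazol-1-yl)methyl.

Going by the values given here, the only measured single-change step, from compound 1 to compound 3, alters the aniline side and not the chain, so it does not bear on this change. Among the compounds with values here, compound 2, the one compound with a different chain, gives a higher number, though its aniline also differs. In the absence of a matching precedent, compound 4 is expected to lie close to compound 1, with a modest move towards a higher number considered somewhat more likely, as a 1.4-fold higher number from compound 1 to compound 4 (0.13 log units; within the scatter).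

Compound 4 is therefore estimated at 3000 nM, with a range from 1200 nM to 8000 nM.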

Compound 4, half-maximal inhibitory concentration: > 50000 nM
Compound 4 ended at the assay's limit; the forecaster's own chance of this, stated with the estimate: 5%; middle value at least 16-fold (1.22 log units) from the limit.
By their numbers in this assay, from the lowest: compounds 3 and 1 (each within the scatter of the next); then compound 2. At a limit, above all of these: compound 4.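

In this assay compound 4 gives > 50000 nM, which is a limit of the assay and not a number: the limit of > 50000 nM in this assay, at which 1 of the 4 values shown sits.

With the aniline side unchanged, putting 2-methyl-5-nitro-1H-imidazol-1-yl in place of 2-(2-nitro-1H-imidazol-1-yl)ethyl gives an at least 22-fold higher number from compound 1 to compound 4 (1.35 log units; beyond the scatter). The earlier change on the aniline side gave only a 1.2-fold lower number from compound 1 to compound 3 (0.07 log units; within the scatter), so this chain position is far less forgiving in these compounds than that aniline change suggested.

The single step alters the chain length, the place of the nitro group on the imidazole and the added methyl together, and the compounds shown cannot separate these three. They also leave open how a longer chain carrying 2-methyl-5-nitro-1H-imidazol-1-yl, or a simple amine at the chain end, would behave.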